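Notes on the step from compound 2 to compound 3

A few compounds are considered here, and "the series" means these few. Any claim that something is new, unique, unknown or untested is made for them only; others in the source may bear on it.

Values below come from a functional assay on HepG2 cells (Homo sapiens) for cytotoxicity, read by MTT assay (on this read-out higher numbers stand for weaker inhibition and lower numbers for stronger inhibition), alone.
- compound 1 `COc1ccc(/C=C/C(=O)c2ccc(OC)c3c2OC(C)(C)C=C3)cc1OC(=O)C(C)C` gives 250 nM
- compound 2 `COc1ccc(/C=C/C(=O)c2ccc(OC)c3c2OC(C)(C)C=C3)cc1OC(=O)c1ccc(Br)cc1` gives 680 nM

Among the compounds with values here, compound 2 holds the higher of the two numbers in this assay so far. The next compound is compound 3 `COc1ccc(/C=C/C(=O)c2ccc(OC)c3c2OC(C)(C)C=C3)cc1OC(=O)c1ccco1`, which differs from compound 2 as follows: furan-2-yl in place of 4-bromophenyl on a carbonyl carbon. In short, furan-2-yl stands in place of 4-bromophenyl on a carbonyl carbon.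

Within the data shown here, one measured step bears on this change: a 2.7-fold higher number from compound 1 to compound 2 (0.43 log units; beyond the scatter). That modest step, beyond the scatter, replaced isopropyl with 4-bromophenyl at the same place. Among the measured compounds shown here, no measured compound carries furan-2-yl, so the guidance is indirect. A small move towards a lower number is expected, no larger than that measured step. The expected change is a 1.7-fold lower number from compound 2 to compound 3 (0.23 log units; within the scatter) in this assay. For compound 3 the estimate is 400 nM, with an expected range of 170 nM to 950 nM.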

Compound 3, half-maximal inhibitory concentration: 370 nM
Estimate against measurement, compound 3: 1.1-fold (0.03 log units) above, within the range that was stated.
By their numbers in this assay, from the lowest: compounds 1, 3 and 2 (each within the scatter of the next, the first and the last beyond it).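

In this assay the step of a 1.8-fold lower number from compound 2 to compound 3 (0.26 log units; within the scatter) and the step of a 1.5-fold higher number from compound 1 to compound 3 (0.17 log units; within the scatter) both lie within the scatter, so furan-2-yl cannot be separated from either 4-bromophenyl or isopropyl at this position. The earlier pair showed only that this carbonyl carbon can register a difference between two groups; compound 3 adds that a five-membered aromatic ring does not fall clearly with either of them, so the three groups do not split into two distinct sets on these numbers. No measurement available here offers an explanation for these numbers.

The compounds shown leave open how the read-out responds to an amine, a carboxylic acid or a longer alkyl chain on this carbonyl carbon. A plain phenyl group would show whether the bromine or the six-membered ring goes with the number of compound 2.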